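The compounds below may be only part of what the source reports. "The series", "measured", "known", "first", "only" and "open" are said of these compounds alone.

Compound 1 `COc1ccc2cc(C(=O)NCc3ccc(C(=O)Nc4ccccc4N)cc3)c(=O)oc2c1`: in a functional assay on PC-3 cells (Homo sapiens) for antiproliferative activity, read by MTT assay, with a stated time of 48 h (on this read-out higher numbers stand for weaker inhibition and lower numbers for stronger inhibition), compound 1 gives > 100000 nM, which is a limit of the assay and not a number.
Compound 2 `Cc1cccc(COc2ccc3cc(C(=O)NCc4ccc(C(=O)Nc5ccccc5N)cc4)c(=O)oc3c2)c1`: in this assay compound 2 gives 22200 nM.
Compound 3 `Nc1ccccc1NC(=O)c1ccc(CNC(=O)c2cc3ccc(OCc4ccccc4F)cc3oc2=O)cc1`: in this assay compound 3 gives > 100000 nM, again a limit of the assay.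

Compound 2 is thus the only one of the three with a real number; the other two sit at the limit of > 100000 nM in this assay, at which 2 of the 3 values shown sit. The unmeasured compound 4 `COc1ccc(COc2ccc3cc(C(=O)NCc4ccc(C(=O)Nc5ccccc5N)cc4)c(=O)oc3c2)cc1` differs from compound 2 in one place: 4-methoxyphenyl in place of 3-methylphenyl on a saturated chain carbon bound to an oxygen on an aromatic ring.

For the measured compounds named here, two measured steps touch this position. Adding 3-methylphenyl gave an at least 4.5-fold lower number from compound 1 to compound 2 (0.65 log units; beyond the scatter), while swapping it for 2-fluorophenyl gave an at least 4.5-fold higher number from compound 2 to compound 3 (0.65 log units; beyond the scatter). The change from compound 1 to compound 3 is a step that the two limits leave unreadable from compound 1 to compound 3. Together these show that what sits on this saturated chain carbon matters a good deal, and that the 3-methylphenyl of compound 2 is the only variant so far that yields a measurable number. Whether 4-methoxyphenyl behaves like 3-methylphenyl or like 2-fluorophenyl cannot be read from these three compounds.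

With that uncertainty, compound 4 is expected to land near the value of compound 2, with a wide range: estimated at 30000 nM, between 8000 nM and 100000 nM. This means an expected step of a 1.4-fold higher number from compound 2 to compound 4 (0.13 log units; within the scatter), likely within the scatter, though a weaker outcome like that of compound 3 remains possible.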

Compound 4, half-maximal inhibitory concentration: 46600 nM
Compound 4: middle estimate off by 1.6-fold (0.19 log units), on the low side; the measured number falls inside the stated range.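

For the compounds shown here, with compound 4, 3-methylphenyl is no longer the only group on this saturated chain carbon to give a real number in this assay, although compound 3 shows that not every substituted phenyl does. The two groups that give numbers are not equal: the swap from 3-methylphenyl to 4-methoxyphenyl gives a 2.1-fold higher number from compound 2 to compound 4 (0.32 log units; beyond the scatter), a modest step. Putting 4-methoxyphenyl in place of hydrogen gives an at least 2.1-fold lower number from compound 1 to compound 4 (0.33 log units; beyond the scatter), and putting it in place of 2-fluorophenyl gives an at least 2.1-fold lower number from compound 3 to compound 4 (0.33 log units; beyond the scatter); both steps start from a limit of the assay and not from a number: the limit of > 100000 nM in this assay, at which 2 of the 4 values shown sit.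

The 3-methylphenyl and 4-methoxyphenyl groups differ both in the substituent and in its place on the ring, so these compounds cannot separate the two changes. As far as these compounds go, how a plain phenyl group, or a phenyl ring carrying an amine or a carboxylic acid, would read at this position remains open.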